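The source may hold more compounds than are shown below. What is called first, only, known or untested is meant among the compounds shown, and "the series" means these compounds.

Measured so far:
- compound 1, `O=S(=O)(Nc1ccc(-c2nc3ccccc3o2)cc1)c1ccc(Cl)s1`: 31000 nM
- compound 2, `CS(=O)(=O)Nc1ccc(-c2nc3ccccc3o2)cc1`: > 100000 nM
- compound 3, `O=S(=O)(Nc1ccc(-c2nc3ccccc3o2)cc1)c1ccccc1O`: > 100000 nM

For the measured compounds named here, in an assay on cells for inhibition of HSP60/HSP10 (Homo sapiens), with a stated time of 60 min (on this read-out lower numbers stand for stronger inhibition and higher numbers for weaker inhibition), compound 1 gives 31000 nM, the only plain number in the set. For compound 2 this assay reports only a limit, > 100000 nM. For compound 3 this assay likewise reports only a limit, > 100000 nM, so compound 3 stands at the weak end of what is shown, (the limit of > 100000 nM in this assay, at which 2 of the 3 values shown sit). The steps from compound 1 are an at least 3.2-fold higher number from compound 1 to compound 2 (0.50 log units; beyond the scatter) and an at least 3.2-fold higher number from compound 1 to compound 3 (0.50 log units; beyond the scatter); the pair compound 2 to compound 3 gives a step that the two limits leave unreadable from compound 2 to compound 3.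

Compound 4, `O=S(=O)(Nc1ccc(-c2nc3ccccc3o2)cc1)c1ccc(O)cc1`, differs from compound 3 in one place: 4-hydroxyphenyl in place of 2-hydroxyphenyl on a sulfonyl sulfur. Going by the values given here, no measured step moves a hydroxyl around the ring on the sulfonyl sulfur; the steps from compound 1 only show that replacing 5-chlorothiophen-2-yl by methyl or by 2-hydroxyphenyl pushes the number to the limit. With compound 3 already at a limit, the expected step of a number no higher from compound 3 to compound 4 (the limit leaves the size open) cannot be read against a number, and compound 4 is expected to sit near the same limit. The estimate for compound 4 in this assay is 100000 nM, within 30000 nM to 300000 nM.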

Compound 4, half-maximal inhibitory concentration: 78000 nM
Beside the measured number, compound 4's estimate is 1.3-fold (0.11 log units) above it; low and high end bracket the measured number.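

In this assay, for the compounds shown here, the 4-hydroxyphenyl group of compound 4 gives the first plain number for a hydroxyphenyl on the sulfonyl sulfur, so this group can be set directly against 5-chlorothiophen-2-yl: a 2.5-fold higher number from compound 1 to compound 4 (0.40 log units; beyond the scatter). The comparisons with the two limit compounds give only floors, an at least 1.2-fold lower number from compound 3 to compound 4 (0.10 log units; that floor lies within the scatter) and an at least 1.2-fold lower number from compound 2 to compound 4 (0.10 log units; that floor lies within the scatter), so neither moving the hydroxyl around the ring nor exchanging methyl for 4-hydroxyphenyl is shown to change the read-out. Compound 1 remains the strongest of the four, with all its steps beyond the scatter, while the step between the two limit compounds cannot be read: the limit of > 100000 nM in this assay, at which 2 of the 4 values shown sit.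

Open, from the compounds shown here alone, is whether the step away from 5-chlorothiophen-2-yl follows the chlorine, which an unsubstituted thiophen-2-yl or a 4-chlorophenyl on the sulfonyl sulfur would help to separate. Also open, going by these compounds, is how a 4-aminophenyl or a 4-carboxyphenyl would read in this place, and whether any group on the sulfonyl sulfur gives a lower number than compound 1.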